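A few compounds are considered here, and "the series" means these few. Any claim that something is new, unique, unknown or untested is made for them only; others in the source may bear on it.

Among the measured compounds shown here, in a functional assay on P388 cells (Mus musculus) for cytotoxicity (on this read-out higher numbers stand for weaker inhibition and lower numbers for stronger inhibition), compound 1 `C=C/C=C\[C@H](C)[C@H](OC(N)=O)[C@@H](C)[C@H](O)[C@@H](C)C/C(C)=C\[C@H](C)[C@@H](O)[C@@H](C)/C=C\[C@@H](O)C[C@@H]1OC(=O)C(C)=C[C@H]1C` gives 33.6 nM, the only true number available in this small series. Compound 2 `C=C/C=C\[C@H](C)[C@H](OC(N)=O)[C@@H](C)[C@H](OC(C)=O)[C@@H](C)C/C(C)=C\[C@H](C)[C@@H](OC(C)=O)[C@@H](C)/C=C\[C@@H](O)C[C@@H]1OC(=O)C(C)=C[C@H]1C` stands apart from it. Compound 2 gives > 7580 nM, which is a limit of the assay and not a number. Its real position is therefore unknown, and any step that starts from it can only be approximate.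

Compound 3 `C=C/C=C\[C@H](C)[C@H](OC(N)=O)[C@@H](C)[C@H](O)[C@@H](C)C/C(C)=C\[C@H](C)[C@@H](OC(C)=O)[C@@H](C)/C=C\[C@@H](O)C[C@@H]1OC(=O)C(C)=C[C@H]1C` is derived from compound 2 by one change, acetoxy to hydroxy: hydrogen in place of acetyl on an oxygen on a saturated carbon. Hydrogen takes the place of acetyl on an oxygen on a saturated carbon whose other neighbours are saturated chain carbon.

For the measured compounds named here, no step between measured compounds is available as a guide, so the expectation rests on the two end points alone. A clear move towards stronger inhibition in this assay is expected, beyond the scatter, though probably not reaching the level of compound 1 at 33.6 nM. The estimated change is an at least 18-fold lower number from compound 2 to compound 3 (1.27 log units; beyond the scatter). For compound 3 the expected value is 400 nM, with an estimated range from 80 nM to 3000 nM.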

Compound 3, half-maximal inhibitory concentration: 519 nM
Compound 3: the middle estimate sits 1.3-fold (0.11 log units) below what was measured; measured number inside the range.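

In this assay, replacing acetyl with hydrogen on just one of the two acetylated oxygens gives an at least 14-fold lower number from compound 2 to compound 3 (1.16 log units; beyond the scatter), so a single acetoxy to hydroxy change is enough to bring a measurable number back. The acetoxy that remains in compound 3 still carries a large cost, since acetyl in place of hydrogen on that one oxygen gives a 15-fold higher number from compound 1 to compound 3 (1.19 log units; beyond the scatter), a step that, unlike the one from the doubly acetylated compound, joins two true numbers and so shows the size of a single acetylation directly. The starting point of the first step is a limit of the assay and not a number, which leaves that step open-ended: the limit of > 7580 nM in this assay, at which 1 of the 3 values shown sits.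

Going by these compounds, what remains open is how the other singly acetylated arrangement, with hydroxy and acetoxy exchanged between the two oxygens, would read in this assay, and so whether the two oxygens tolerate acetyl equally. On these data alone, it is also open whether the large step belongs to acetyl in particular or would recur with a methyl ether or a longer acyl chain such as butyryl on the same oxygen.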